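Swapping Chloro for Bromo: What Compound 3 Might Give

The compounds below may be only part of what the source reports. "The series", "measured", "known", "first", "only" and "open" are said of these compounds alone.

Compound 2 `Clc1ccc([C@H]2CC(c3ccccc3)=NN2c2ncc(Br)cn2)cc1` gives 61% in a functional assay on the whole organism (strain Wistar albino) for inhibition, with Rattus norvegicus as the target, read by paw edema, with stated times of 30 min and 0.5 h, at a dose of 20 mg/kg; on this read-out lower numbers stand for less inhibition and higher numbers for more inhibition at the one dose given (going by the name of the read-out). Its only measured companion, compound 1 `Cc1ccc([C@H]2CC(c3ccccc3)=NN2c2ncc(Br)cn2)cc1`, gives 63% in this assay; compound 2 thus has the lower of the two numbers, yet the gap between them lies within the scatter. Compound 3 `Brc1ccc([C@H]2CC(c3ccccc3)=NN2c2ncc(Br)cn2)cc1` differs from compound 2 in one place: bromo in place of chloro on an aromatic carbon. Among the measured compounds shown here, the single comparison that bears on this, a number 2 percentage points lower from compound 1 to compound 2 (within the scatter), was likewise a swap of one small group for another on an aromatic carbon and moved the number only within the scatter. A step of about a number 1 percentage points lower from compound 2 to compound 3 (within the scatter) is therefore expected, no larger than the scatter. Compound 3 is estimated at 60%, between 48% and 72%.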

Compound 3, a percentage reported as inhibition, in the whole organism at one dose (the size of the read-out at that dose, not a potency): 64%
For compound 3 the middle estimate is 4 percentage points below the measured one; measured number inside the range.
By their numbers in this assay, from the lowest: compounds 2, 1 and 3 (each within the scatter of the next).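

With a number 3 percentage points higher from compound 2 to compound 3 (within the scatter) and a number 1 percentage points higher from compound 1 to compound 3 (within the scatter) in this assay, methyl, chloro and bromo on this aromatic carbon, para to a large group, now all lie within the scatter of one another. The earlier pair compared only methyl with chloro; this result adds that exchanging one halogen for another also gives no change that can be told from the scatter. No evidence here explains why these three groups cannot be told apart. As far as these compounds go, whether an amine, a carboxylic acid or a longer chain at this place would give a clearly different number remains open.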